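Cyclopropanecarboxamide series: aryl swap on the cyclopropane

A few compounds are considered here, and "the series" means these few. Any claim that something is new, unique, unknown or untested is made for them only; others in the source may bear on it.

Measured compounds:
Compound 1 `CC(C)CCCN(C(=O)[C@@H]1C[C@H]1c1ccccc1)c1ccc(-c2ccccc2)cc1`: in a functional assay for agonist activity at G protein-coupled receptor 88 (Homo sapiens), read by HTRF and cAMP accumulation (a lower number here means that less compound is needed, a higher number that more compound is needed for the effect), compound 1 reports only an assay limit, > 100 nM.
Compound 2 `O=C([C@@H]1C[C@H]1c1ccccc1)N(CCNCC1CCCCC1)c1ccc(-c2ccccc2)cc1`: in this assay compound 2 gives 6.6 nM.
Compound 3 `CC[C@H](C)[C@H](N)CN(C(=O)[C@@H]1C[C@H]1c1ccc(Cl)cc1)c1ccc(-c2ccccc2)cc1`: in this assay compound 3 gives 4300 nM.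

Compound 3 holds the highest of the two numbers in hand; compound 2 is the nearest and sits far below it, and the remaining entry is the limit of compound 1 (the limit of > 100 nM in this assay, at which 1 of the 3 values shown sits).

Compound 4 `CC[C@H](C)[C@H](N)CN(C(=O)[C@@H]1C[C@H]1c1ccncc1)c1ccc(-c2ccccc2)cc1` differs from compound 3 in one place: pyridin-4-yl in place of 4-chlorophenyl on a saturated ring carbon.

For the measured compounds named here, the only measured step, an at least 15-fold lower number from compound 1 to compound 2 (1.18 log units; beyond the scatter), concerns the group on the amide-type nitrogen, not the aromatic ring on the cyclopropane, so it says nothing about this swap. Going by the values given here, no measured step bears on the change, and the shared core of compound 3 carries the same amine-bearing chain in both.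

Among the compounds with values here, with no comparable step to draw on, the expected step of a 1.4-fold higher number from compound 3 to compound 4 (0.14 log units; within the scatter) is taken as modest and uncertain, with a wide range. In this assay compound 4 is therefore expected at 6000 nM, estimated between 1500 nM and 25000 nM.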

Compound 4, half-maximal effective concentration: 1500 nM
The estimate for compound 4 lay 4.0-fold (0.60 log units) above the measured number, within the range that was stated.
By their numbers in this assay, from the lowest: compound 2; then compound 4; then compound 3.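

At this position on the cyclopropane, the aromatic ring can be changed with a readable result in this assay: a 2.9-fold lower number from compound 3 to compound 4 (0.46 log units; beyond the scatter). For the compounds shown here, this is the first measured step at this place, since the earlier step concerned the group on the amide-type nitrogen, and here the amine-bearing chain stays the same while a carbon-only ring gives way to a ring with one hetero atom and one hydrogen-bond acceptor. Nothing measured here accounts for the size of this step.

Going by these compounds, the swap removes the chlorine and adds the ring nitrogen at once, so the share of each stays open, and a plain phenyl or a pyrimidine ring on this same chain would help to separate them. On these data alone, whether pyridin-4-yl gives a similar step alongside the (cyclohexylmethyl)amino chain of compound 2 also remains open.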